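Fluorine shift on the benzyl group, compound 3 to compound 4

The compounds below may be only part of what the source reports. "The series", "measured", "known", "first", "only" and "open" are said of these compounds alone.

Among the measured compounds shown here, compound 3 `CC1(C)c2[nH]nc(NC(=O)c3ccccc3)c2CN1Cc1cccc(F)c1F` gives the lowest number of the three measured so far in an assay on Sf21 cells for inhibition of high affinity nerve growth factor receptor (Homo sapiens), read by HTRF, with a stated time of 30 min, in the presence of a further agent that is not named here (on this read-out higher numbers stand for weaker inhibition and lower numbers for stronger inhibition), at 200 nM. Its nearest neighbour is compound 2 `CC1(C)c2[nH]nc(NC(=O)c3ccccc3)c2CN1Cc1ccccc1F`, which in this assay gives 450 nM; the step of a 2.3-fold lower number from compound 2 to compound 3 (0.35 log units; beyond the scatter) lies beyond the scatter. Furthest is compound 1 `Cc1cccc(CN2Cc3c(NC(=O)c4ccccc4)n[nH]c3C2(C)C)c1`, which in this assay gives 1100 nM; the step of a 5.5-fold lower number from compound 1 to compound 3 (0.74 log units; beyond the scatter) and the step of a 2.4-fold lower number from compound 1 to compound 2 (0.39 log units; beyond the scatter) are both beyond the scatter, both modest.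

Compound 4 `CC1(C)c2[nH]nc(NC(=O)c3ccccc3)c2CN1Cc1cc(F)ccc1F` is not yet measured. Its change from compound 3 is 2,5-difluorophenyl in place of 2,3-difluorophenyl on a saturated chain carbon bound to an amine nitrogen in a ring; the two have the same atoms, joined differently. For the measured compounds named here, no measured step relocates a fluoro from one aromatic carbon to another. The closest guide is a 2.3-fold lower number from compound 2 to compound 3 (0.35 log units; beyond the scatter), where a fluoro entered in place of hydrogen, and a 2.4-fold lower number from compound 1 to compound 2 (0.39 log units; beyond the scatter), where the benzyl substituent pattern changed. As the fluorine count stays the same, the expected step of a 1.3-fold higher number from compound 3 to compound 4 (0.10 log units; within the scatter) is small, in no direction beyond the scatter. Compound 4 is estimated at 250 nM in this assay, in the range 100 nM to 600 nM.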

Compound 4, half-maximal inhibitory concentration: 480 nM
Estimate against measurement, compound 4: 1.9-fold (0.28 log units) below, and the stated range covers the measured number.
By their numbers in this assay, from the lowest: compound 3; then compounds 2 and 4 (each within the scatter of the next); then compound 1.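

Relocating one fluoro within the benzyl group is enough to produce a 2.4-fold higher number from compound 3 to compound 4 (0.38 log units; beyond the scatter) in this assay and this shows that the 2,3-difluorophenyl and 2,5-difluorophenyl groups are not interchangeable at this position, although their atom counts are identical. A second fluoro does not lower the number regardless of where it sits: the change gives a 1.1-fold higher number from compound 2 to compound 4 (0.03 log units; within the scatter) and that step stays within the scatter, so among the compounds shown only the 2,3-difluorophenyl pattern improves on the single fluoro, while a 2.3-fold lower number from compound 1 to compound 4 (0.36 log units; beyond the scatter) still stands beyond the scatter. Nothing available here explains the difference between the two patterns.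

Open, as far as these compounds go, is whether a chloro or methoxy group on the benzyl ring would match the 2,3-difluorophenyl group. Also open, from the compounds shown here alone, is whether that pattern keeps its advantage when the phenyl of the amide carries an amine or a carboxylic acid.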